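The source may report more compounds than this note shows. Statements on the series, on what has been measured and on what is new or still open speak of the compounds shown alone.

Measured so far:
- compound 1 `COc1ccc(CN2CCC(CCNC(=O)/C=C/c3cc(C(C)(C)C)c(O)c(C(C)(C)C)c3)CC2)cc1`: 61200 nM
- compound 2 `CC(C)(C)c1cc(/C=C/C(=O)NCCC2CCN(Cc3ccccc3Cl)CC2)cc(C(C)(C)C)c1O`: 80200 nM

Going by the values given here, in a functional assay, read by spectrophotometry, with a stated time of 30 min (on this read-out higher numbers stand for weaker inhibition and lower numbers for stronger inhibition), compound 2 gives 80200 nM, a number that cannot be told apart from the one for compound 1, given the usual scatter of such measurements. Compound 3 `CC(C)(C)c1cc(/C=C/C(=O)NCCC2CCN(Cc3cccc(Cl)c3)CC2)cc(C(C)(C)C)c1O` has not yet been measured. It has the same atoms as compound 2, joined differently, and only the place of the chlorine on the phenyl group changes: 3-chlorophenyl in place of 2-chlorophenyl on a saturated chain carbon bound to an amine nitrogen in a ring.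

Among the compounds with values here, no measured pair shows a chlorine moved on its own, so the evidence is indirect. Within the data shown here, the one step that bears on this change is a 1.3-fold higher number from compound 1 to compound 2 (0.12 log units; within the scatter). It put 2-chlorophenyl in place of 4-methoxyphenyl at the same place and stayed within the scatter. Among the measured compounds shown here, with only this step as a guide, no shift beyond the scatter is expected in this assay, in either direction. The expected step is a 1.1-fold lower number from compound 2 to compound 3 (0.06 log units; within the scatter). The estimate for compound 3 is 70000 nM, with an expected range from 35000 nM to 140000 nM.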

Compound 3, half-maximal inhibitory concentration: 83100 nM
Estimate against measurement, compound 3: 1.2-fold (0.07 log units) below; the measured number falls inside the stated range.
By their numbers in this assay, from the lowest: compounds 1, 2 and 3 (each within the scatter of the next).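

In this assay, shifting the chlorine on the phenyl group gives a 1.0-fold higher number from compound 2 to compound 3 (0.02 log units; within the scatter), so 2-chlorophenyl and 3-chlorophenyl cannot be told apart at this place, on a saturated chain carbon bound to an amine nitrogen in a ring. Going by these compounds alone, this is the first pair in which the place of the chlorine is the only difference, whereas the earlier step exchanged 4-methoxyphenyl for a chlorine-bearing group and so changed both the substituent and its place. Replacing 4-methoxyphenyl with 3-chlorophenyl gives a 1.4-fold higher number from compound 1 to compound 3 (0.13 log units; within the scatter), so all three substituted phenyl groups shown now lie within the scatter of one another, and no supporting measurement is available to explain this closeness.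

From the compounds shown here alone, it remains open whether 4-chlorophenyl would also fall within the scatter of these three, which would complete the set of chlorine places on the phenyl group. Going by these compounds, it is also open whether a more different group at this place, such as a phenyl group carrying a carboxylic acid or an amine, or a longer chain, would produce a step beyond the scatter.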